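This account rests on a few compounds, and the source may have more. Where it says the series, first, only, none or still open, it means among the compounds named here.

In an ADME assay on MT4 cells (Homo sapiens) for cytotoxicity, read by MTT assay, with a stated time of 5 days (on this read-out higher numbers stand for lower toxicity in this test and lower numbers for higher toxicity in this test), compound 1 (`CCCCCNc1cc(Oc2c(OC)cc3cc(C#N)ccc3c2OC)nc(Nc2ccc(C#N)cc2)n1`) gives > 125000 nM, which is a limit of the assay and not a number. Compound 2 (`COc1cc2cc(C#N)ccc2c(OC)c1Oc1cc(NC2CCCCC2)nc(Nc2ccc(C#N)cc2)n1`) gives > 125000 nM, and this too is only a limit, so its true position on the scale is not known. Going by the values given here, the one measured step, a step that the two limits leave unreadable from compound 1 to compound 2, therefore has no size that can be carried forward. Both measured compounds share the same limit, as the limit of > 125000 nM in this assay, at which 2 of the 2 values shown sit, records.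

Compound 3 (`COc1cc2cc(C#N)ccc2c(OC)c1Oc1cc(NCCCCO)nc(Nc2ccc(C#N)cc2)n1`) keeps the core of compound 2 and changes one group, with 4-hydroxybutyl in place of cyclohexyl on a nitrogen on an aromatic ring. Among the compounds with values here, neither measured compound carries a 4-hydroxybutyl group, so this change has no direct precedent. Pentyl and cyclohexyl on that nitrogen both stay at the limit, which gives no reason to expect a large step in this assay, though a modest move toward higher toxicity remains possible. The expected change is an at least 1.1-fold lower number from compound 2 to compound 3 (0.05 log units; that floor lies within the scatter). Compound 3 is estimated at 110000 nM, with an expected range from 40000 nM to 125000 nM.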

Compound 3, half-maximal cytotoxic concentration: 39100 nM
The estimate for compound 3 lay 2.8-fold (0.45 log units) above the measured number, outside the stated range (below it).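

In this assay, the group on a nitrogen on an aromatic ring proves able to move the read-out toward higher toxicity in this test: 4-hydroxybutyl in place of cyclohexyl gives an at least 3.1-fold lower number from compound 2 to compound 3 (0.50 log units; beyond the scatter). Hydroxy in place of methyl on a saturated chain carbon, four bonds along the chain from that nitrogen, gives an at least 3.1-fold lower number from compound 1 to compound 3 (0.50 log units; beyond the scatter), so this one-place change, which involves no ring, is enough to bring the read-out to a number, and both steps are floors whose true size may be larger. The step between the two earlier compounds cannot be read, and they alone showed only a shared limit of the assay at this position: the limit of > 125000 nM in this assay, at which 2 of the 3 values shown sit.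

As far as these compounds go, how much larger either step really is stays open, since each starts from a limit, and a single hydroxy-bearing chain cannot show whether the shift belongs to the hydroxy alone or would vary with chain length. From the compounds shown here alone, whether an amine or a carboxylic acid in place of that hydroxy, or a longer chain carrying it, would give a lower or a higher number also remains unknown.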